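The source may hold more compounds than are shown below. What is called first, only, known or untested is meant among the compounds shown, and "the series" means these compounds.

In an assay on isolated protein for inhibition of histone deacetylase 4 (Homo sapiens), with a stated time of 1 h (on this read-out higher numbers stand for weaker inhibition and lower numbers for stronger inhibition), compound 2 `O=C(COc1ccc2cc(/C=C3/SC(=O)NC3=O)ccc2c1)Nc1ccc(F)cc1F` gives 3900 nM, the highest of the three numbers measured here. Compound 1 `O=C(COc1ccc2cc(/C=C3/SC(=O)NC3=O)ccc2c1)Nc1ccc(Br)cc1F` gives 1900 nM and compound 3 `O=C(COc1ccc2cc(/C=C3/SC(=O)NC3=O)ccc2c1)Nc1ccc(F)cc1` gives 1600 nM. The steps of a 2.1-fold higher number from compound 1 to compound 2 (0.31 log units; beyond the scatter) and a 2.4-fold lower number from compound 2 to compound 3 (0.39 log units; beyond the scatter) both lie beyond the usual scatter of this read-out, while the step of a 1.2-fold lower number from compound 1 to compound 3 (0.07 log units; within the scatter) stays within it.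

The unmeasured compound 4 `O=C(COc1ccc2cc(/C=C3/SC(=O)NC3=O)ccc2c1)Nc1ccc(Cl)c(Cl)c1` differs from compound 2 in one place: 3,4-dichlorophenyl in place of 2,4-difluorophenyl on an amide-type nitrogen. Two of the measured steps bear on this. The loss of a fluoro from the ring on the amide-type nitrogen is the kind of change seen in a 2.4-fold lower number from compound 2 to compound 3 (0.39 log units; beyond the scatter), which gave a lower number, and the exchange of fluoro for a heavier halogen is the reverse of a 2.1-fold higher number from compound 1 to compound 2 (0.31 log units; beyond the scatter), which gave a higher number. Both point toward a lower number for compound 4 than for compound 2. For the measured compounds named here, no measured compound carries the second chlorine of the 3,4-dichlorophenyl group, so that part of the change has no comparison and widens the uncertainty.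

Compound 4 is therefore expected to give about 1500 nM, with a likely range from 500 nM to 4500 nM. The expected step is a 2.6-fold lower number from compound 2 to compound 4 (0.41 log units; beyond the scatter), a modest move toward stronger inhibition.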

Compound 4, half-maximal inhibitory concentration: 5500 nM
Estimate against measurement, compound 4: 3.7-fold (0.56 log units) below, and the stated range ends below it.
By their numbers in this assay, from the lowest: compounds 3 and 1 (each within the scatter of the next); then compounds 2 and 4 (each within the scatter of the next).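

Putting 3,4-dichlorophenyl in place of 2,4-difluorophenyl on the amide-type nitrogen brings no clear change in this assay (a 1.4-fold higher number from compound 2 to compound 4 (0.15 log units; within the scatter)), so two chlorines on this ring do not repeat the lower number that went with bromo in compound 1. The same group stands clearly higher when set against the two rings with the lower numbers (a 3.4-fold higher number from compound 3 to compound 4 (0.54 log units; beyond the scatter); a 2.9-fold higher number from compound 1 to compound 4 (0.46 log units; beyond the scatter)), which means that a heavier halogen on this ring does not by itself lead to stronger inhibition: compound 1 fits that idea, whereas compound 4 goes against it. Nothing shown here accounts for this difference between the bromo and dichloro rings.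

On these data alone, it remains open whether a single chlorine on this ring would behave like the pair, since the two chlorines of compound 4 cannot be told apart by these compounds. Every ring shown carries only halogens, so it is also open how a methoxy group, an amine or a carboxylic acid on the ring would compare.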